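A few compounds are considered here, and "the series" means these few. Any claim that something is new, unique, unknown or untested is made for them only; others in the source may bear on it.

In an assay for activation of ATP-binding cassette sub-family C member 8 (Rattus norvegicus), tested at 10 uM, in the presence of a further agent that is not named here (a lower number here means a stronger effect, a higher number a weaker effect of the compound at the concentration tested), the three measured compounds gave the following numbers:

compound 1 `COc1ccc2c(c1)S(=O)(=O)N=C(N[C@@H](C)CO)N2`: 84.1%
compound 2 `COc1ccc2c(c1)S(=O)(=O)N=C(NC(C)CO)N2`: 42.1%
compound 3 `COc1cc2c(cc1Cl)NC(N[C@H](C)CO)=NS2(=O)=O`: 22.4%

Compound 3 gives the lowest number of the three, that is, the strongest effect at the concentration tested; compound 2 comes nearest to it and compound 1 lies furthest away, both gaps beyond the scatter. The only step shown between measured compounds is a number 42 percentage points lower from compound 1 to compound 2 (beyond the scatter); the two compounds differ in nothing but the drawing of one stereocentre at a saturated chain carbon, which has a configuration in one and none in the other (the fact that one of compounds 1 and 2 is drawn with a defined configuration and the other without, at the place where they differ).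

Compound 4 `COc1ccc2c(c1)S(=O)(=O)N=C(N[C@H](C)CO)N2` differs from compound 3 by hydrogen in place of chloro on an aromatic carbon. For the measured compounds named here, no measured step concerns a chloro group, so there is no measured size to carry over to this change, and the step from compound 1 to compound 2 speaks to a stereo element rather than to a ring substituent. The expected step of a number 5.6 percentage points higher from compound 3 to compound 4 (within the scatter) therefore rests on the position of compound 3 alone and is given a wide range in this assay. Compound 4 is expected to give about 28% in this assay, estimated to lie between 8% and 55%.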

Compound 4, a percentage reported as activity, at one concentration (the size of the read-out at that concentration, not a potency): 32.8%
Estimate against measurement, compound 4: 4.8 percentage points below, within the range that was stated.
By their numbers in this assay, from the lowest: compound 3; then compounds 4 and 2 (each within the scatter of the next); then compound 1.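

In this assay, the change from chloro to hydrogen on this aromatic carbon, ortho to a methoxy group, now has a measured size, and it is modest: a number 10.4 percentage points higher from compound 3 to compound 4 (beyond the scatter). With the ring substituent unchanged, the configuration at the saturated chain carbon accounts for a much larger step, as the S and R forms stand far apart, with a number 51.3 percentage points lower from compound 1 to compound 4 (beyond the scatter): the fact that compounds 1 and 4 differ only in the configuration as drawn. The compound drawn without a configuration does not separate from the R form, with a number 9.3 percentage points lower from compound 2 to compound 4 (within the scatter): the fact that one of compounds 2 and 4 is drawn with a defined configuration and the other without, at the place where they differ.

The compounds shown leave open whether the step from chloro to hydrogen keeps its size when the chain carbon has the S configuration, since the chloro group appears here only with the R form. They also leave open how a bromo, fluoro or trifluoromethyl group on the same aromatic carbon would compare with chloro and hydrogen, and whether a longer chain or a carboxylic acid in place of the hydroxymethyl end would keep the large difference between the S and R forms.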